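The compounds below may be only part of what the source reports. "The series", "measured", "known", "first", "only" and "open" are said of these compounds alone.

Values so far in a functional assay on SK-OV-3 cells (Homo sapiens) for antiproliferative activity, read by MTT assay, with a stated time of 72 h; a higher number here means a weaker inhibitor, a lower number a stronger inhibitor:
compound 1 `O=C(CCc1cccc2c1B(O)OC2)Nc1ccc(F)cc1`: 720 nM
compound 2 `C#Cc1cccc(NC(=O)CCc2cccc3c2B(O)OC3)c1`: 980 nM
compound 3 `O=C(CCc1cccc2c1B(O)OC2)Nc1cccc(-c2ccccc2)c1`: 250 nM

Compound 3 at 250 nM has the lowest of the three numbers, and the values of compound 1 and compound 2 both lie beyond the scatter from it. The next case is compound 4 `COc1cc(OC)cc(-c2cccc(NC(=O)CCc3cccc4c3B(O)OC4)c2)c1`, which carries 3,5-dimethoxyphenyl in place of phenyl on an aromatic carbon is the full count of the change.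

For the measured compounds named here, only one measured step bears on this: a 3.9-fold lower number from compound 2 to compound 3 (0.59 log units; beyond the scatter) is a modest step for phenyl in place of ethynyl on an aromatic carbon. Going by the values given here, no measured compound carries a substituted phenyl, so the data give no direct reading of this change and only weak support for any direction. The expected step in this assay is small: a 1.3-fold lower number from compound 3 to compound 4 (0.10 log units; within the scatter) is the estimate, within the scatter and with a wide margin on either side. For compound 4 the estimated value is 200 nM with an expected range from 60 nM to 650 nM for now.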

Compound 4, half-maximal inhibitory concentration: 44 nM
The estimate for compound 4 lay 4.5-fold (0.66 log units) above the measured number; measured number outside the range, below it.
By their numbers in this assay, from the lowest: compound 4; then compound 3; then compounds 1 and 2 (each within the scatter of the next).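

This aromatic carbon still responds after ethynyl has given way to phenyl: substituting the phenyl itself moves the number further, with 3,5-dimethoxyphenyl giving a modest step in this assay (a 5.7-fold lower number from compound 3 to compound 4 (0.75 log units; beyond the scatter)). Taken from the ethynyl compound, the same group gives a large step (a 22-fold lower number from compound 2 to compound 4 (1.35 log units; beyond the scatter)), so the earlier reading on plain phenyl did not mark the end of what this position can give. No measurement at hand explains the step.

Still open, going by these compounds, is whether both methoxy groups are needed, or whether a single methoxy on the same phenyl would give a step of similar size. Also open, on these data alone, is how a hydroxyl, an amine or a carboxylic acid at those places on the phenyl would read in this assay.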